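The source may hold more compounds than are shown below. What is called first, only, known or untested is meant among the compounds shown, and "the series" means these compounds.

Measured compounds:
- compound 1 `Cl[C@H]1CCO[C@@H](c2ccccc2)C1`: > 100000 nM, a limit of the assay
- compound 2 `O=[N+]([O-])c1ccc([C@H]2C[C@@H](Cl)CCO2)cc1`: > 100000 nM, a limit of the assay
- compound 3 `CC(C)C[C@H]1C[C@@H](Cl)C[C@@H](c2ccccc2)O1`: 24000 nM

In a functional assay on SW1573 cells (Homo sapiens) for antiproliferative activity (on this read-out lower numbers stand for stronger inhibition of growth and higher numbers for weaker inhibition of growth), compound 1 gives only a limit. In this assay compound 2 likewise gives only a limit. The step that the two limits leave unreadable from compound 1 to compound 2 therefore cannot be sized; the change is nitro in place of hydrogen on an aromatic carbon, and the limit of > 100000 nM in this assay, at which 2 of the 3 values shown sit, is all that can be said of it. Among the compounds with values here, compound 3 is the one compound of the three with an actual number in this assay.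

Compound 4 `CC(C)C[C@H]1C[C@@H](Cl)C[C@@H](c2ccc([N+](=O)[O-])cc2)O1` is not yet measured. It differs from compound 3 by nitro in place of hydrogen on an aromatic carbon, the same kind of change as that from compound 1 to compound 2; around the place the two differ, the group entering in compound 4 sitting para to a large group, that in compound 2 para to a group of 7 heavy atoms. The difference between the two cores is not broken down here.

With the earlier step unreadable, the step from compound 3 to compound 4 in this assay is estimated at a 1.3-fold higher number from compound 3 to compound 4 (0.10 log units; within the scatter), resting only on the value of compound 3, which gives 24000 nM. Compound 4 is thus expected near 30000 nM, between 8000 nM and 100000 nM.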

Compound 4, concentration for 50% growth inhibition: 30000 nM
Estimate against measurement, compound 4: no gap at the digits printed; measured number inside the range.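

In this assay, nitro in place of hydrogen on an aromatic carbon gives a 1.3-fold higher number from compound 3 to compound 4 (0.10 log units; within the scatter), so on the core of compound 3 the change leaves no difference that can be told from the usual scatter. The same change on the core of compound 1 cannot be read, since compound 1 and compound 2 both give only a limit: the limit of > 100000 nM in this assay, at which 2 of the 4 values shown sit. The pair of compound 3 and compound 4 is therefore the only readable case, and it does not show that the change behaves alike on the two cores, nor does one pair set a rule for the series.

As far as these compounds go, what an amine or a carboxylic acid would give in place of the nitro on the core of compound 3 remains open. Also open, from the compounds shown here alone, is whether a longer chain in place of the branched chain shared by compound 3 and compound 4 would move the number in this assay.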